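The source may report more compounds than this note shows. Statements on the series, on what has been measured and on what is new or still open speak of the compounds shown alone.

Among the measured compounds shown here, compound 1 `O=C(Nc1cccc(S(=O)(=O)N2CCCC2)c1)c1cccnc1N1CCC2(CC1)CC2` gives 4420 nM in a functional assay on OVCAR-3 cells (Homo sapiens) for antiproliferative activity (on this read-out lower numbers stand for an effect already at smaller amounts and higher numbers for an effect only at larger amounts of compound), the highest of the three numbers measured so far. Compound 2 `CC(C)(C)NS(=O)(=O)c1cccc(NC(=O)c2ccc(NC3(CO)CC3)cc2N2CCC3(CC2)CC3)n1` gives 62 nM in this assay, and compound 3 `CC(C)(C)NS(=O)(=O)c1cccc(NC(=O)c2ccc(NC(C)(C)CO)cc2N2CCC3(CC2)CC3)n1` gives 23 nM, both being built on a different core from compound 1. For the measured compounds named here, the single measured step, a 2.7-fold lower number from compound 2 to compound 3 (0.43 log units; beyond the scatter), alters a group on a nitrogen on an aromatic ring and does not touch the sulfonyl. Compound 4 `CC(C)S(=O)(=O)c1cccc(NC(=O)c2cccnc2N2CCC3(CC2)CC3)c1` differs from compound 1 at one place only: isopropyl in place of pyrrolidin-1-yl on a sulfonyl sulfur. Going by the values given here, no measured step bears on this kind of change, so nothing here points to a shift beyond the scatter in either direction. Compound 4 is therefore expected to give about 4400 nM, within 1500 nM to 13000 nM, which amounts to an expected 1.0-fold lower number from compound 1 to compound 4 (0.00 log units; within the scatter).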

Compound 4, half-maximal effective concentration: 4480 nM
Beside the measured number, compound 4's estimate is 1.0-fold (0.01 log units) below it; low and high end bracket the measured number.
By their numbers in this assay, from the lowest: compound 3; then compound 2; then compounds 1 and 4 (each within the scatter of the next).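

In this assay putting isopropyl in place of pyrrolidin-1-yl on the sulfonyl sulfur gives a 1.0-fold higher number from compound 1 to compound 4 (0.01 log units; within the scatter) and so leaves the two compounds indistinguishable. Among the compounds shown here, this is the first measured change at the sulfonyl, and it shows that on this core the ring and its nitrogen can be lost without a change beyond the scatter. Nothing at hand explains why the number holds. Going by these compounds, whether the same swap behaves alike on the core of compound 2 stays open, as does the effect of a carboxylic acid or an amine on a chain at this sulfonyl sulfur.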